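Efficacy notes on a thiazole acetic acid series

This account rests on a few compounds, and the source may have more. Where it says the series, first, only, none or still open, it means among the compounds named here.

Three compounds carry measured values. Compound 1 `CS(=O)(=O)Nc1cccc(-c2nc(C(c3ccc(F)cc3)c3ccc(F)cc3)sc2CC(=O)O)c1` in an in vitro functional assay on HEK285-7 cells for antagonist activity at prostaglandin D2 receptor 2 (Homo sapiens), read by BRET and beta-arrestin recruitment (on this read-out higher numbers stand for larger maximal responses and lower numbers for smaller maximal responses), gives 80%, the largest maximal response among the three. Compound 2 `CCC(c1ccccc1)c1nc(-c2ccc(Cl)cc2)c(CC(=O)O)s1` in this assay gives 50%, a value that lies below compound 1 by more than the usual scatter. Compound 3 `O=C(O)Cc1sc(NCc2ccccc2)nc1-c1ccc(Cl)cc1` in this assay gives 30%, further below compound 1 again beyond the scatter. Compounds 2 and 3 differ from compound 1 in more than one place, so no single change is tied to either of these gaps.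

Compound 4 `CN(C)c1cc(-c2nc(C(c3ccc(F)cc3)c3ccc(F)cc3)sc2CC(=O)O)ccn1` is the next compound and has not yet been measured. It differs from compound 1 in one place: 2-(dimethylamino)pyridin-4-yl in place of 3-(methanesulfonamido)phenyl on an aromatic carbon The group that leaves carries one hydrogen-bond donor; the group that enters carries none, and it is an aromatic ring with one hetero atom in place of one of carbon only.

Among the compounds with values here, no measured pair shows a change of this kind, so the expectation rests on compound 1 alone. A small downward step, of a size near the edge of the scatter, is expected, because compound 1 already gives 80% and the other two compounds sit below it. The step from compound 1 to compound 4 is estimated as a number 12 percentage points lower from compound 1 to compound 4 (beyond the scatter). Compound 4 is expected to give about 68%, within a range from 45% to 90%.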

Compound 4, largest response reached (reported as efficacy), in percent of the reference or control that the assay uses: 80%
Estimate against measurement, compound 4: 12 percentage points below, within the range that was stated.
By their numbers in this assay, from the lowest: compound 3; then compound 2; then compounds 1 and 4 (each within the scatter of the next).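

In this assay, within the data shown here, placing 2-(dimethylamino)pyridin-4-yl instead of 3-(methanesulfonamido)phenyl on the aromatic carbon next to the ring nitrogen gives the first single-place step, and it reads no change at the digits printed from compound 1 to compound 4 (within the scatter). At this position, therefore, the maximal response is held across a change that removes the hydrogen-bond donor, replaces a ring of carbon only with a ring carrying a hetero atom, and swaps the methanesulfonamido group for a dimethylamino group, although this rests on one pair only. No measurement is available that accounts for the response being held across this change.

The compounds shown leave open whether a plain phenyl ring, with neither substituent, or a 3-aminophenyl group at the same position would also hold the response, so the contribution of each substituent cannot be separated from that of the ring carrying it. Going by these compounds, compounds 2 and 3 differ from compound 1 and compound 4 in more than one place, so steps to them cannot be read, and whether this tolerance extends to other groups elsewhere on the shared core remains untested within this set.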